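Cytotoxicity notes on shortening the hydroxamate linker

The source may hold more compounds than are shown below. What is called first, only, known or untested is meant among the compounds shown, and "the series" means these compounds.

Among the measured compounds shown here, the two measured members share one core and differ only in the substituent on the aromatic nitrogen. Compound 1 is `C=CC(=O)Nc1cc2c(Nc3ccc(F)c(Cl)c3)ncnc2cc1OCc1cn(CCCCC(=O)NO)nn1`. In an ADME assay on FHC cells (Homo sapiens) for cytotoxicity, read by MTT assay, with a stated time of 72 h (on this read-out higher numbers stand for weaker inhibition and lower numbers for stronger inhibition), compound 1 gives > 25000 nM, which is a limit of the assay rather than a number. Compound 2 is `C=CC(=O)Nc1cc2c(Nc3cccc(Cl)c3F)ncnc2cc1OCc1cn(CCCCC(=O)NO)nn1`. In this assay compound 2 gives > 25000 nM, again a limit of the assay and not a number. The step that the two limits leave unreadable from compound 1 to compound 2 therefore has no readable size, and the limit of > 25000 nM in this assay, at which 2 of the 2 values shown sit, is all that describes where compound 2 stands: at the limit, alongside the other measured value, with nothing to order the two.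

Compound 3 is `C=CC(=O)Nc1cc2c(Nc3cccc(Cl)c3F)ncnc2cc1OCc1cn(CCC(=O)NO)nn1`. It differs from compound 2 by hydroxycarbamoyl in place of 2-(hydroxycarbamoyl)ethyl on a saturated chain carbon, two bonds along the chain from an aromatic nitrogen. For the measured compounds named here, no measured step touches this chain; the single measured step, a step that the two limits leave unreadable from compound 1 to compound 2, is unreadable and concerns another part of the molecule. With both measured values at the limit, the step expected in this assay is a step that the limit leaves unreadable from compound 2 to compound 3, most likely again ending at a limit. Compound 3 is expected at 30000 nM, with a range from 12000 nM to 100000 nM.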

Compound 3, half-maximal inhibitory concentration: > 25000 nM
Compound 3 ended at the assay's limit; the forecaster's own chance of this, stated with the estimate: 85%; the middle value lies beyond the limit too.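

In this assay, among the compounds shown here, compound 2 and compound 3 both give limits rather than numbers, so no step between them can be read, and hydroxycarbamoyl in place of 2-(hydroxycarbamoyl)ethyl has no readable size. All the compounds shown stand at one value: the limit of > 25000 nM in this assay, at which 3 of the 3 values shown sit.

On these data alone, what stays open is whether any change to this series brings a measurable value within the range of the assay.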